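The source may report more compounds than this note shows. Statements on the series, on what has been measured and on what is new or still open speak of the compounds shown alone.

Compound 1, `Cc1ccc(C(=O)N2N=C(c3ccc(N4CCN(C)CC4)cc3)CC2c2ccc(N(C)C)cc2)cc1`, gives -0.4% in a functional assay on NCI-H1975 cells (Homo sapiens) for inhibition, read by sulforhodamine B assay, tested at 10 uM; on this read-out higher numbers stand for more inhibition at the one concentration tested (going by the name of the read-out) and lower numbers for less inhibition; compound 2, `CN1CCN(c2ccc(C3=NN(C(=O)c4ccc(F)cc4)C(c4ccc(N(C)C)cc4)C3)cc2)CC1`, gives 32.2%; compound 3, `Cc1ccc(S(=O)(=O)N2N=C(c3ccc(-n4cncn4)cc3)CC2c2ccc(N(C)C)cc2)cc1`, gives 20%.

Compound 1 and compound 2 share a core and differ in one place: fluoro in place of methyl on an aromatic carbon. This single exchange gave a number 32.6 percentage points higher from compound 1 to compound 2 (beyond the scatter). Compound 4, `CN(C)c1ccc(C2CC(c3ccc(-n4cncn4)cc3)=NN2S(=O)(=O)c2ccc(F)cc2)cc1`, has not yet been measured. It differs from compound 3 by fluoro in place of methyl on an aromatic carbon, the same change at the same place, although here it reads (4-methylphenyl)sulfonyl to (4-fluorophenyl)sulfonyl rather than (4-methylphenyl)carbonyl to (4-fluorophenyl)carbonyl. The difference between the core of compound 1 and the core of compound 3 is not broken down here.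

Within the data shown here, only one earlier example of this exchange is available, on a different core, so the expectation rests on it alone. Compound 4 is expected to gain over compound 3 by about a number 22 percentage points higher from compound 3 to compound 4 (beyond the scatter), a somewhat smaller rise than the earlier one because the step of a number 32.6 percentage points higher from compound 1 to compound 2 (beyond the scatter) was seen on another core. Compound 4 is estimated at 42%, with a plausible range from 15% to 68%.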

Compound 4, a percentage reported as inhibition, at one concentration (the size of the read-out at that concentration, not a potency): -0.5%
Compound 4: middle estimate off by 42.5 percentage points, on the high side, outside the stated range (below it).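

In this assay, fluoro in place of methyl gave a number 20.5 percentage points lower from compound 3 to compound 4 (beyond the scatter), so the rise seen on the core of compound 1 did not carry over to the core of compound 3. Set side by side, the two steps point in opposite directions: the same change on two cores in this assay, a number 32.6 percentage points higher (beyond the scatter) from compound 1 to compound 2 and a number 20.5 percentage points lower (beyond the scatter) from compound 3 to compound 4, 53.1 percentage points apart, beyond the scatter of two such steps

This shows that, in these two pairs, the outcome of the exchange depends on the core that carries it, so a step measured on one core is a poor guide to the step on the other; it does not show which feature of the two cores is responsible, or how the exchange would behave on a third core.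

The compounds shown leave open whether another group at that same place on the aromatic ring, such as chloro, methoxy or an amine, would also behave differently on the two cores. Each core is seen here with only methyl and fluoro, so any trend on either core rests on a single pair.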